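A few compounds are considered here, and "the series" means these few. Any claim that something is new, unique, unknown or untested is made for them only; others in the source may bear on it.

Three compounds sharing a core were examined in a functional assay on EA.hy 926 cells (Homo sapiens) for cytotoxicity, read by MTT assay, with stated times of 24 h and 12 h; a lower number here means that less compound is needed, a higher number that more compound is needed for the effect. Compound 1 `COc1ccc(/C=C/C(=O)O)c(OC(=O)c2nc(C)c(C)nc2C)c1` gives 115000 nM, and compound 2 `CCOC(=O)/C=C/c1ccc(OC)cc1OC(=O)c1nc(C)c(C)nc1C` gives 138000 nM. The change from compound 1 to compound 2 is ethyl in place of hydrogen on an oxygen next to a carbonyl group; the step was a 1.2-fold higher number from compound 1 to compound 2 (0.08 log units; within the scatter). Compound 3 `COc1ccc(/C=C/C(=O)O)cc1OC(=O)c1nc(C)c(C)nc1C` gives 8800 nM, and its steps to compound 1 and to compound 2 lie beyond the scatter. Compound 3 has the same atoms as compound 1, joined differently; the difference between the two cores is not broken down here.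

Compound 4 `CCOC(=O)/C=C/c1ccc(OC)c(OC(=O)c2nc(C)c(C)nc2C)c1` has not yet been measured. It differs from compound 3 by ethyl in place of hydrogen on an oxygen next to a carbonyl group, the same kind of change that leads from compound 1 to compound 2. Since that earlier step stayed within the scatter, as shown by a 1.2-fold higher number from compound 1 to compound 2 (0.08 log units; within the scatter), the step from compound 3 to compound 4 is expected to be about as small, around a 1.2-fold higher number from compound 3 to compound 4 (0.08 log units; within the scatter). The expectation for compound 4 in this assay is therefore 10500 nM, with a range from 5000 nM to 25000 nM.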

Compound 4, half-maximal effective concentration: 29900 nM
Compound 4: middle estimate off by 2.8-fold (0.45 log units), on the low side; the whole stated range lies below it.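

In this assay, changing carboxy to ethoxycarbonyl on the core of compound 3 gives a 3.4-fold higher number from compound 3 to compound 4 (0.53 log units; beyond the scatter), so on this core, adding the ethyl group raises the amount of compound needed for the effect. The earlier pair behaved differently, which means the size of this step did not carry over unchanged from one core to the other: the same change on two cores in this assay, a 1.2-fold higher number (0.08 log units; within the scatter) from compound 1 to compound 2 and a 3.4-fold higher number (0.53 log units; beyond the scatter) from compound 3 to compound 4, 2.8-fold (0.45 log units) apart, beyond the scatter of two such steps These two pairs do not show why the cores respond differently, and they cannot predict how large the step would be on a further core.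

The compounds shown carry only the carboxy group and its ethyl ester at this place, leaving open what a methyl ester, a longer chain such as a butyl ester, or an amide would do on either core. From the compounds shown here alone, it also remains open whether any such group could match compound 3, which gives 8800 nM, the lowest number among the compounds that carry its core.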